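Heteroaryl swap on the fused core: cytotoxicity notes

The source may report more compounds than this note shows. Statements on the series, on what has been measured and on what is new or still open speak of the compounds shown alone.

Compound 1 `Cn1cccc1-c1nc2cc(C(=O)NC3(C(=O)Nc4ccc(/C=C/C(=O)O)cc4)CCC3)ccc2n1C1CCCCC1` and compound 2 `O=C(O)/C=C/c1ccc(NC(=O)C2(NC(=O)c3ccc4c(c3)nc(-c3cccs3)n4C3CCCCC3)CCC2)cc1` share the whole scaffold and differ only in the five-membered heteroaryl attached to the fused core. In an ADME assay on Huh-7 cells (Homo sapiens) for cytotoxicity (a lower number here means that less compound is tolerated, a higher number that more compound is tolerated), compound 1 reaches only the limit > 10 uM. In this assay compound 2 likewise reaches only the limit > 10 uM. The step that the two limits leave unreadable from compound 1 to compound 2 therefore cannot be read, as both values sit at the same limit (the limit of > 10 uM in this assay, at which 2 of the 2 values shown sit). Among the compounds with values here, compound 2 thus stands at the limit of this assay with no numerical value, and the single further value shown beside it is a limit as well.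

Compound 3 `O=C(O)/C=C/c1ccc(NC(=O)C2(NC(=O)c3ccc4c(c3)nc(-c3ccco3)n4C3CCCCC3)CCC2)cc1` carries the change (furan-2-yl in place of thiophen-2-yl on an aromatic carbon). Within the data shown here, the one measured step, from compound 1 to compound 2, bears on this change only in kind, and it is unreadable, so neither a size nor a direction can be taken from it. Since both measured compounds sit at the limit (the limit of > 10 uM in this assay, at which 2 of the 2 values shown sit), compound 3 is expected to sit there too, and the step that the limit leaves unreadable from compound 2 to compound 3 is expected to stay within the scatter. Compound 3 is accordingly estimated at 20 uM, within 8 uM to 60 uM.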

Compound 3, half-maximal toxic concentration: > 10 uM
Compound 3 was reported as a limit; the forecaster's own chance of this, stated with the estimate: 80%; the middle value is on the limit's open side.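

No new step can be read among compound 1, compound 2 and compound 3, as all three values are limits: the limit of > 10 uM in this assay, at which 3 of the 3 values shown sit.

The compounds shown leave open whether 1-methyl-1H-pyrrol-2-yl, thiophen-2-yl and furan-2-yl differ at all in this assay, and what numerical half-maximal toxic concentration any of the three compounds has.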